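The source may report more compounds than this note shows. Statements on the series, on what has been measured and on what is new or still open speak of the compounds shown alone.

In a functional assay on OVCAR-3 cells (Homo sapiens) for antiproliferative activity, read by MTT assay, with a stated time of 24 h (on this read-out higher numbers stand for weaker inhibition and lower numbers for stronger inhibition), compound 1 `O=C(NNc1ccc(F)cc1)c1cccc(NS(=O)(=O)c2cnc(O)nc2O)c1` gives > 20000 nM as a limit of the assay and not a number. On the numbers shown, compound 1 stands at the limit of > 20000 nM in this assay, at which 1 of the 2 values shown sits, and so has no measured position in the series. Compound 2 `O=C(NNC(=O)c1cccc(Cl)c1)c1ccc(NS(=O)(=O)c2cnc(O)nc2O)cc1` gives 7710 nM as a true number in the same read-out.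

Compound 3 `O=C(NNC(=O)c1cccc(NS(=O)(=O)c2cnc(O)nc2O)c1)c1ccc(F)cc1` is still to be measured. Relative to compound 1 it carries (4-fluorophenyl)carbonyl in place of 4-fluorophenyl on an amine nitrogen and keeps the rest of the structure. Going by the values given here, no measured pair isolates this change, and the starting point is only a limit, so the size of the step remains loose.

The direction expected in this assay is towards stronger inhibition, with an estimated at least 1.8-fold lower number from compound 1 to compound 3 (0.25 log units; that floor lies within the scatter) as a modest move at best. Among the compounds with values here, the only numerical anchor is compound 2 at 7710 nM in this series. A reading that again reaches the assay limit remains possible. For compound 3 the expected value is 11000 nM with an estimated range from 4500 nM to 20000 nM in this assay.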

Compound 3, half-maximal inhibitory concentration: > 20000 nM
Compound 3: no number, only a limit; the forecaster's own chance of this, stated with the estimate: 35%; at least 1.8-fold (0.25 log units) between middle value and limit.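

In this assay compound 3 gives > 20000 nM, a limit of the assay and not a number. Compound 1 also stands at a limit, so no step can be read between compound 1 and compound 3: the limit of > 20000 nM in this assay, at which 2 of the 3 values shown sit.

The compounds shown leave open whether (4-fluorophenyl)carbonyl in place of 4-fluorophenyl on an amine nitrogen changes inhibition at all.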